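A few compounds are considered here, and "the series" means these few. Any claim that something is new, unique, unknown or untested is made for them only; others in the source may bear on it.

The three measured compounds share one core and differ in the group carried on the amine nitrogen of the six-membered non-aromatic ring. Compound 1 `CCCc1nc(-c2ccccc2)c(CNCCCN2CCN(c3ccccc3)CC2)o1` carries an unsubstituted phenyl there, and in an assay on HEK293 cells for inhibition of Voltage-dependent T-type calcium channel subunit alpha-1G (Homo sapiens), read by fluorescence, tested at 10 uM (on this read-out higher numbers stand for more inhibition at the one concentration tested (going by the name of the read-out) and lower numbers for less inhibition), compound 1 gives 43.7%. Compound 2 `CCCc1nc(-c2ccccc2)c(CNCCCN2CCN(c3ccccc3C(F)(F)F)CC2)o1` gives 45%, and compound 3 `CCCc1nc(-c2ccccc2)c(CNCCN2CCN(c3cccc(C(F)(F)F)c3)CC2)o1` gives 56.3%, the highest of the three numbers; its margins over compound 2 and over compound 1 both lie beyond the scatter. Compound 4 `CCCc1nc(-c2ccccc2)c(CNCCN2CCN(c3ccc(F)cc3)CC2)o1` has not yet been measured; it differs from compound 3 by 4-fluorophenyl in place of 3-(trifluoromethyl)phenyl on an amine nitrogen in a ring. For the measured compounds named here, only one measured step bears on this change: a number 1.3 percentage points higher from compound 1 to compound 2 (within the scatter), where a trifluoromethyl entered without a shift beyond the scatter. Compounds 2 and 3 differ in more than one place, so their gap cannot be attributed to the trifluoromethyl alone. On that basis the removal of the trifluoromethyl while a fluorine enters is expected to move the number little, with the step estimated as a number 8.3 percentage points lower from compound 3 to compound 4 (within the scatter). Compound 4 is therefore estimated at 48%, within a range from 30% to 65%.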

Compound 4, a percentage reported as inhibition, at one concentration (the size of the read-out at that concentration, not a potency): 54.1%
Estimate against measurement, compound 4: 6.1 percentage points below, and the stated range covers the measured number.
By their numbers in this assay, from the lowest: compounds 1, 2, 4 and 3 (each within the scatter of the next, the first and the last beyond it).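

In this assay the exchange at this position gives a number 2.2 percentage points lower from compound 3 to compound 4 (within the scatter). For the compounds shown here, on the amine nitrogen in the six-membered non-aromatic ring, 3-(trifluoromethyl)phenyl can therefore give way to 4-fluorophenyl, with fewer heavy atoms and the fluorine in place of the trifluoromethyl, without a shift beyond the scatter, something the earlier compounds did not show, as none of them pairs two different substituted phenyl groups in one-place comparison. Nothing available here explains why the two groups read alike.

As far as these compounds go, whether a carboxylic acid, a nitrile or an amine on that phenyl would keep the number in the same region remains open. From the compounds shown here alone, it also remains open whether 4-fluorophenyl reads the same on the longer chain that compound 1 carries.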